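Replacing thiophen-3-yl with 3-cyanophenyl in compound 1

This account rests on a few compounds, and the source may have more. Where it says the series, first, only, none or still open, it means among the compounds named here.

Measured so far in an in vitro ADME assay on microsomes from liver (Homo sapiens) for metabolic stability; a higher number here means faster removal of the compound, a lower number slower removal
- compound 1 `O=C(Nc1cccnc1-c1ccsc1)N1CCN2C(=O)N([C@H]3C[C@@H]3c3ccccc3)C(=O)[C@@H]2C1` gives 40000 mL.min-1.g-1
- compound 2 `O=C(Nc1c(Cl)cc(F)cc1Cl)N1CCN2C(=O)N([C@H]3C[C@@H]3c3ccccc3)C(=O)[C@@H]2C1` gives 64000 mL.min-1.g-1

Going by the values given here, these are the only two numbers so far, and compound 1 and compound 2 lie within the scatter of each other.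

Compound 3 `N#Cc1cccc(-c2ncccc2NC(=O)N2CCN3C(=O)N([C@H]4C[C@@H]4c4ccccc4)C(=O)[C@@H]3C2)c1` keeps the core of compound 1 and carries 3-cyanophenyl in place of thiophen-3-yl on an aromatic carbon. Among the compounds with values here, no measured compound carries 3-cyanophenyl, so no measured step covers this exchange directly. Within the data shown here, the only step that bears on it puts 2,6-dichloro-4-fluorophenyl in place of 2-(thiophen-3-yl)pyridin-3-yl on an amide-type nitrogen (a 1.6-fold higher number from compound 1 to compound 2 (0.20 log units; within the scatter)). That single step stays within the scatter, which is thin support, but on that basis no step beyond the scatter is expected in this assay and no direction can be favoured. The expected step is small (a 1.1-fold higher number from compound 1 to compound 3 (0.05 log units; within the scatter)). For compound 3 the estimated value is 45000 mL.min-1.g-1 (expected range 20000 mL.min-1.g-1 to 100000 mL.min-1.g-1).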

Compound 3, intrinsic clearance in microsomes: 37000 mL.min-1.g-1
Compound 3: the middle estimate sits 1.2-fold (0.09 log units) above what was measured; the range from low to high includes it.
By their numbers in this assay, from the lowest: compounds 3, 1 and 2 (each within the scatter of the next).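

In this assay, putting 3-cyanophenyl in place of thiophen-3-yl on the aromatic carbon next to the ring nitrogen gives no step beyond the scatter (a 1.1-fold lower number from compound 1 to compound 3 (0.03 log units; within the scatter)), although a group of 8 heavy atoms replaces one of 5 and a six-membered aromatic ring of carbon only replaces a five-membered one with 1 hetero atom. Going by these compounds alone, this is the first reading of this position on its own, as the earlier exchange between compound 1 and compound 2 replaced the whole 2-(thiophen-3-yl)pyridin-3-yl group and could not isolate the substituent on this carbon. No measurement is available to explain why the number stays within the scatter across this exchange.

Whether a plain phenyl, a methyl group or an amine on this carbon would also stay within the scatter of compound 1 remains open, and the compounds shown do not separate the contribution of the nitrile from that of the phenyl ring carrying it. Also open, going by these compounds, is whether any change to the shared core, rather than on this carbon, would move the number in this assay beyond the scatter of compound 1.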